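The source may hold more compounds than are shown below. What is called first, only, known or untested is meant among the compounds shown, and "the series" means these compounds.

Measured so far:
- compound 1, `COc1ccc(Nc2cccnc2)cc1`, which in a functional assay on HeLa cells (Homo sapiens) for cytotoxicity, read by MTT assay, with a stated time of 72 h (a lower number here means a stronger inhibitor, a higher number a weaker inhibitor), gives 145000 nM
- compound 2, `COc1ccc(Nc2nc3ccccc3cc2-c2ccc(C)cc2)cc1`, which in this assay gives 102000 nM
- compound 3, `COc1ccc(Nc2cc(-c3cccc(C(F)(F)F)c3)ccn2)cc1`, which in this assay gives 140000 nM

All three numbers are high, meaning only weak effects on the cells. Compound 3 stands second highest of the three. Its nearest neighbour is compound 1, whose number is within the scatter of it, and compound 2 also lies within the scatter, so no order among these three can be read from the data.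

Compound 4, `CCc1ccc(Nc2cc(-c3cccc(C(F)(F)F)c3)ccn2)cc1`, differs from compound 3 in one place:

ethyl in place of methoxy on an aromatic carbon

Going by the values given here, no two measured compounds differ in exactly one place, so no measured step tells how such a swap plays out here. Since compounds that differ considerably in their structures all land close together in this assay, no step beyond the scatter is expected from this change, in either direction. Compound 4 is therefore estimated to give about 130000 nM in this assay, with a range from 60000 nM to 280000 nM. The step this estimate means, a 1.1-fold lower number from compound 3 to compound 4 (0.03 log units; within the scatter), is expected to stay within the scatter.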

Compound 4, half-maximal inhibitory concentration: > 200000 nM
Compound 4: only a limit was reported; the forecaster's own chance of this, stated with the estimate: 20%; middle value at least 1.5-fold (0.18 log units) away from the limit.
By their numbers in this assay, from the lowest: compounds 2, 3 and 1 (each within the scatter of the next). At a limit, above all of these: compound 4.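

Going by these compounds alone, this is the first measured swap at this position, on an aromatic carbon para to a large group: with ethyl entering in place of methoxy, this assay shows an at least 1.4-fold higher number from compound 3 to compound 4 (0.15 log units; that floor lies within the scatter). Compound 4 has a limit and not a number, so the step has a floor but no known size: the limit of > 200000 nM in this assay, at which 1 of the 4 values shown sits. That floor lies within the scatter, so the loss of one hydrogen-bond acceptor is not tied to any firm change, although nothing suggests that ethyl strengthens the effect on the cells.

As far as these compounds go, whether an amine, a carboxylic acid or a longer chain at this position would give a clearly lower number remains open. Also open, from the compounds shown here alone, is what ethyl would do on the cores of compound 1 and compound 2, which carry the same methoxy.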